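The source may hold more compounds than are shown below. What is called first, only, known or untested is meant among the compounds shown, and "the series" means these compounds.

Measured compounds:
Compound 1 `O=C(Nn1c(-c2cccc([N+](=O)[O-])c2)nc2c(-c3ccc(Cl)cc3)n[nH]c2c1=O)c1cccnc1`, which in a functional assay on DU-145 cells (Homo sapiens) for cytotoxicity, read by sulforhodamine B assay, with a stated time of 2 days, tested at 100 uM (a higher number here means more inhibition at the concentration tested (going by the name of the read-out), a lower number less inhibition), gives 31%.
Compound 2 `COc1cccc(-c2nc3c(-c4ccc(C5CCNCC5)cc4)n[nH]c3c(=O)n2NC(=O)c2ccncc2)c1`, which in this assay gives 37%.
Compound 3 `COc1cccc(-c2nc3c(-c4ccco4)n[nH]c3c(=O)n2NC(=O)c2cccnc2)c1`, which in this assay gives 30.1%.

Among these three numbers compound 1 stands second highest. Its nearest neighbour is compound 3, whose value lies a little lower, a gap that falls within the usual scatter of repeated measurements. The furthest from it is compound 2, whose value lies somewhat higher, and that gap too stays within the scatter. The three compounds therefore cannot be told apart on the numbers shown, and no single structural change between any two of them has been measured.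

The step under consideration leads from compound 1 to compound 4 `O=C(Nn1c(-c2cccc([N+](=O)[O-])c2)nc2c(-c3cccs3)n[nH]c2c1=O)c1cccnc1`. The change is thiophen-2-yl in place of 4-chlorophenyl on an aromatic carbon. Going by the values given here, nothing among the measured compounds shows what this exchange does, so the expectation rests on the fact that all three measured compounds sit close together in this assay and the exchanged group is of a similar kind to the ones that vary among them. The step is therefore expected to be small, and it may not reach beyond the scatter in either direction: the estimated change is a number 1 percentage points lower from compound 1 to compound 4 (within the scatter). Compound 4 is thus estimated at 30%, with a range from 15% to 45%.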

Compound 4, a percentage reported as inhibition, at one concentration (the size of the read-out at that concentration, not a potency): 32.8%
Compound 4: the middle estimate sits 2.8 percentage points below what was measured; low and high end bracket the measured number.
By their numbers in this assay, from the lowest: compounds 3, 1, 4 and 2 (each within the scatter of the next).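

In this assay, going by these compounds alone, the exchange of 4-chlorophenyl for thiophen-2-yl on an aromatic carbon of the five-membered aromatic ring with 2 nitrogen gives a number 1.8 percentage points higher from compound 1 to compound 4 (within the scatter), the first step in this set that can be read at a single place. It shows that, with the rest of compound 1 held fixed, this position takes a five-membered aromatic ring with 1 hetero atom and 5 heavy atoms in place of a six-membered aromatic ring of carbon only with 7 heavy atoms, and the read-out stays within the scatter. No measurement at hand accounts for this outcome.

Both groups in this step are single aromatic rings, so the compounds shown leave open how the read-out responds at this position to a carboxylic acid, a morpholine ring or a longer alkyl chain. They also leave open whether the same exchange would give a similar step when the other parts of the molecule differ, as they do in compound 2 and compound 3.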